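A methoxy group added to compound 2

This account rests on a few compounds, and the source may have more. Where it says the series, first, only, none or still open, it means among the compounds named here.

Compound 1 `Cn1ncc2c(NS(=O)(=O)c3cccc(Cl)c3Cl)ccnc21`: >= 310000 nM (a limit)
Compound 2 `Cn1ncc2c(NS(=O)(=O)c3cccc(Cl)c3Cl)ncnc21`: 476000 nM

Both results come from a physicochemical assay for solubility, read by chemiluminescence, measured as kinetic solubility; a lower number here means a less soluble compound, a higher number a more soluble compound. The result for compound 1 is a limit and not a number. Among the compounds with values here, compound 2 therefore holds the only actual number, 476000 nM, and no order between the two can be read.

Compound 3 `COc1nn(C)c2ncnc(NS(=O)(=O)c3cccc(Cl)c3Cl)c12` differs from compound 2 by one change: methoxy in place of hydrogen on an aromatic carbon. Within the data shown here, no measured pair shows this change in this assay. A modest fall is expected, possibly none beyond the scatter. The expected change is a 1.6-fold lower number from compound 2 to compound 3 (0.20 log units; within the scatter). Compound 3 is estimated at 300000 nM, with an expected range of 120000 nM to 560000 nM.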

Compound 3, solubility: >= 581000 nM
Compound 3 gave a limit, no number; the forecaster's own chance of this, stated with the estimate: 30%; middle value at least 1.9-fold (0.28 log units) from the limit.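

In this assay, methoxy in place of hydrogen on an aromatic carbon of the five-membered ring gives an at least 1.2-fold higher number from compound 2 to compound 3 (0.08 log units; that floor lies within the scatter). The result for compound 3 is a limit and not a number: the limit of >= 581000 nM in this assay, at which 1 of the 3 values shown sits. This single change at this position therefore shows no fall in the number, only a floor on the step.

As far as these compounds go, the true size of the step stays open, as only a floor can be read. Also open, from the compounds shown here alone, is how an amine, a carboxylic acid or a longer chain on this same carbon would read.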